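Dropping a methoxy from an inactive dienone-coumarin hybrid

A few compounds are considered here, and "the series" means these few. Any claim that something is new, unique, unknown or untested is made for them only; others in the source may bear on it.

compound 1 `COc1ccccc1/C=C/C(=O)/C=C/c1ccc(OCc2cn(CCCOc3cc(=O)oc4ccccc34)nn2)c(OC)c1`: "not active" (no number reported)
compound 2 `COc1ccc(/C=C/C(=O)/C=C/c2ccc(OCc3cn(CCCCCOc4cc(=O)oc5ccccc45)nn3)c(OC)c2)cc1`: "not active" (no number reported)
compound 3 `COc1cc(/C=C/C(=O)/C=C/c2cc(OC)c(OC)c(OC)c2)ccc1OCc1cn(CCOc2cc(=O)oc3ccccc23)nn1`: 22%

Three compounds share a core built from a dienone, a triazole and a coumarin, all tested in a functional assay on PC-3 cells (Homo sapiens) for inhibition, read by sulforhodamine B assay, with a stated time of 48 h, tested at 50 uM; a lower number here means less inhibition of growth, a higher number more inhibition of growth at the concentration tested. Compound 2 stands without a single number, as in this assay compound 2 is reported "not active" (no number reported); compound 1 is reported the same way, "not active" (no number reported). Only compound 3 carries a number, giving 22% in this assay. Compound 4 `COc1cc(/C=C/C(=O)/C=C/c2ccccc2)ccc1OCc1cn(CCCCCOc2cc(=O)oc3ccccc23)nn1` has not yet been measured. It differs from compound 2 by hydrogen in place of methoxy on an aromatic carbon. Within the data shown here, with no step between measured compounds to lean on, a change of this size is expected to stay within the scatter of this assay, with no clear direction. Compound 4 is therefore estimated at 10%, in the range 0% to 30%.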

Compound 4, percent growth inhibition at one concentration: "not active" (no number reported)
Nothing numeric was reported for compound 4; the estimate stays without a comparison.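

Compound 2 gives "not active" (no number reported) and compound 4 gives "not active" (no number reported) so no step can be read between them. What the 4-methoxyphenyl to phenyl change does to growth inhibition stays open, and no measurement shown offers an explanation.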